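This account rests on a few compounds, and the source may have more. Where it says the series, first, only, none or still open, it means among the compounds named here.

Measured compounds:
compound 1 `CCOc1ccc2ccc(=O)oc2c1CCC(C)C` — 5800 nM
compound 2 `CCCCCCCOc1ccc2ccc(=O)oc2c1CCC(C)C` — 17000 nM

In a functional assay on V79 cells (Cricetulus griseus) for cytotoxicity (a lower number here means a stronger inhibitor, a higher number a weaker inhibitor), compound 2 gives 17000 nM, the highest of the two numbers in hand; its nearest neighbour is compound 1, which gives 5800 nM. Going by the values given here, the only step measured so far, a 2.9-fold higher number from compound 1 to compound 2 (0.47 log units; beyond the scatter), lengthens the alkoxy chain on the shared core. Compound 3 `CCCC(=O)c1ccc2ccc(=O)oc2c1CCC(C)C` differs from compound 2 by propylcarbonyl in place of heptyloxy on an aromatic carbon. Among the compounds with values here, no measured step exchanges an alkoxy group for a carbonyl group, so the one guide is that the shorter chain of compound 1 went with the lower number, 5800 nM, and the entering propylcarbonyl is shorter than the leaving heptyloxy. As far as these compounds go, on that slim basis the step of a 2.1-fold lower number from compound 2 to compound 3 (0.33 log units; beyond the scatter) is expected to run downward, though the exchange of oxygen for a carbonyl is untested here. Compound 3 is estimated at 8000 nM in this assay, with a range from 3000 nM to 25000 nM.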

Compound 3, half-maximal inhibitory concentration: 58000 nM
Compound 3: the middle estimate sits 7.3-fold (0.86 log units) below what was measured, outside the stated range (above it).
By their numbers in this assay, from the lowest: compound 1; then compound 2; then compound 3.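

In this assay, the size of the group alone does not order the numbers at this aromatic carbon. Propylcarbonyl has fewer heavy atoms than heptyloxy, yet the exchange gives a 3.4-fold higher number from compound 2 to compound 3 (0.53 log units; beyond the scatter), so compound 3 goes against the lower number that came with the shorter chain of compound 1, and the exchange for ethoxy gives a 10-fold higher number from compound 1 to compound 3 (1.00 log units; beyond the scatter). Both alkoxy compounds thus stand below the carbonyl compound, which shows that the kind of group at this position matters as well as its chain length, though nothing in hand explains the rise.

The compounds shown leave open whether the higher number goes with the carbonyl itself or with the chain it carries: a propoxy group or a longer chain on the carbonyl would separate the two. As far as these compounds go, how an amine or a carboxylic acid would read at this carbon also remains open.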